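Adding a second phenyl at the chain carbon of compound 3

The source may report more compounds than this note shows. Statements on the series, on what has been measured and on what is new or still open speak of the compounds shown alone.

Measured compounds:
compound 1 `COC(=O)NC(CC(=O)N1CCC(Cn2c(C)nc3cnccc32)CC1)c1ccccc1` gives 12 nM
compound 2 `Cc1nc2cnccc2n1C1CCN(C(=O)CC(c2ccccc2)c2ccccc2)CC1` gives 100 nM
compound 3 `Cc1nc2cnccc2n1CC1CCN(C(=O)CCc2ccccc2)CC1` gives 60 nM

These three compounds were tested in a functional assay (plasma) with Oryctolagus cuniculus as the target; a lower number here means a stronger inhibitor, a higher number a weaker inhibitor. Compound 3 stands second highest of the three numbers; its nearest neighbour is compound 2, and the gap between them lies within the scatter, while compound 1 sits furthest away, with a number a 5.0-fold higher number from compound 1 to compound 3 (0.70 log units; beyond the scatter) apart. That single step, a 5.0-fold higher number from compound 1 to compound 3 (0.70 log units; beyond the scatter), is the only one at the same saturated chain carbon, and it shows that a group there can shift the number by a modest amount.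

Compound 4 `Cc1nc2cnccc2n1CC1CCN(C(=O)CC(c2ccccc2)c2ccccc2)CC1` has not yet been measured. It differs from compound 3 in one place: phenyl in place of hydrogen on a saturated chain carbon bound to an aromatic carbon and a saturated chain carbon. For the measured compounds named here, no measured step adds a phenyl anywhere, so the only direct guide is the observation that compound 2, which also carries two phenyl groups on that chain carbon but lacks the methylene on the other side, gives 100 nM, close to compound 3. On this basis compound 4 is expected to land near compound 3, with a step of about a 1.2-fold higher number from compound 3 to compound 4 (0.07 log units; within the scatter), not beyond the scatter, and an estimated value of 70 nM (range 25 nM to 200 nM).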

Compound 4, half-maximal inhibitory concentration: 7.6 nM
Compound 4: middle estimate off by 9.2-fold (0.96 log units), on the high side; measured number outside the range, below it.
By their numbers in this assay, from the lowest: compounds 4 and 1 (each within the scatter of the next); then compounds 3 and 2 (each within the scatter of the next).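

In this assay, phenyl in place of hydrogen on a saturated chain carbon bound to an aromatic carbon and a saturated chain carbon gives a 7.9-fold lower number from compound 3 to compound 4 (0.90 log units; beyond the scatter), the first sign that this carbon can take a second phenyl and still give a lower number. The pair of phenyl groups does not set the number alone: with both phenyl groups in place, a group of 11 heavy atoms in place of a group of 10 heavy atoms on a saturated ring carbon gives a 13-fold lower number from compound 2 to compound 4 (1.12 log units; beyond the scatter), so the result also depends on what sits at that other place. Two quite different groups on the chain carbon also cannot be told apart here, as phenyl in place of (methoxycarbonyl)amino gives a 1.6-fold lower number from compound 1 to compound 4 (0.20 log units; within the scatter), a step within the scatter.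

Nothing available here gives a reason for any of these steps. From the compounds shown here alone, it remains open whether an amine or a carboxylic acid on this chain carbon would give a number as low as phenyl does, and whether a longer chain carrying the two phenyl groups would do the same.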